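Purine benzyl series: amino for chloro at compound 4

This account rests on a few compounds, and the source may have more. Where it says the series, first, only, none or still open, it means among the compounds named here.

Three measured members of the series share a core carrying a chloro-bearing benzyl group on a ring nitrogen and differ in where the chloromethyl sits on the benzyl ring and in the number of chloro groups on the core. Compound 1 `ClCc1ccc(Cn2cnc3c(Cl)ncnc32)cc1` has the chloromethyl opposite the point of attachment; in a functional assay on SF-539 cells (Homo sapiens) for cytotoxicity, read by sulforhodamine B assay, with a stated time of 48 h (on this read-out higher numbers stand for weaker inhibition of growth and lower numbers for stronger inhibition of growth), compound 1 gives 2340 nM. Compound 2 `ClCc1ccccc1Cn1cnc2c(Cl)nc(Cl)nc21` carries two chloro groups on the core; in this assay compound 2 gives 1470 nM. Compound 3 `ClCc1cccc(Cn2cnc3ncnc(Cl)c32)c1` shows the widest gap; in this assay compound 3 gives 20000 nM. Compound 2 has the lowest number of the three, but its gap to compound 1 lies within the scatter, so no order between those two can be read; only the gap to compound 3 lies beyond the scatter.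

Compound 4 `Nc1nc(Cl)c2ncn(Cc3ccccc3CCl)c2n1` is not yet measured. Relative to compound 2 the change is amino in place of chloro on an aromatic carbon. Within the data shown here, no measured pair in the set isolates this exchange, so the direction rests on no data. In this assay compound 4 is expected to give 3000 nM, between 1000 nM and 12000 nM, which means an expected step of a 2.0-fold higher number from compound 2 to compound 4 (0.31 log units; beyond the scatter) of modest size, likely not far beyond the scatter.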

Compound 4, concentration for 50% growth inhibition: 18200 nM
Beside the measured number, compound 4's estimate is 6.1-fold (0.78 log units) below it; measured number outside the range, above it.
By their numbers in this assay, from the lowest: compounds 2 and 1 (each within the scatter of the next); then compounds 4 and 3 (each within the scatter of the next).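

In this assay, among these compounds, amino in place of chloro on the aromatic carbon between two ring nitrogen atoms gives a 12-fold higher number from compound 2 to compound 4 (1.09 log units; beyond the scatter), a large step and the first comparison that changes only one place. The earlier compounds shown here could not isolate this position, whereas here the benzyl group with its chloromethyl and the remaining chloro group on the core stay unchanged, and the chloro-bearing compound shows the stronger inhibition of growth. The exchange adds a hydrogen-bond donor and a hydrogen-bond acceptor by count, but no available evidence connects either this difference or any other with the step.

One exchange at one position leaves open whether the step follows from the arrival of amino or the departure of chloro, and a methoxy group, a methylamino group or a plain hydrogen on the same carbon would help separate those readings. Also open, going by these compounds, is whether the same exchange gives a step of similar size when the chloromethyl sits elsewhere on the benzyl ring, or when amino replaces the other chloro group on the core.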